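Dithiocarbamate series: from 4-methylbenzyl to 4-methoxy-3-nitrobenzyl

The source may report more compounds than this note shows. Statements on the series, on what has been measured and on what is new or still open speak of the compounds shown alone.

Measured in a functional assay on KYSE-450 cells (Homo sapiens) for inhibition, read by CCK-8 assay, with a stated time of 48 h (a lower number here means a stronger inhibitor, a higher number a weaker inhibitor), as follows:
- Compound 1 `COc1ccc(CN(C(=O)CSC(=S)N2CCN(C(=O)OC(C)(C)C)CC2)c2ccccc2)cc1` gives > 20000 nM as a limit
- Compound 2 `COc1cc(N(Cc2ccc(C)cc2)C(=O)CSC(=S)N2CCN(C(=O)OC(C)(C)C)CC2)cc(OC)c1OC` gives > 20000 nM as a limit

Compound 2 stands at the limit of > 20000 nM in this assay, at which 2 of the 2 values shown sit, and that is a limit, not a number. Compound 3 `COc1ccc(CN(C(=O)CSC(=S)N2CCN(C(=O)OC(C)(C)C)CC2)c2cc(OC)c(OC)c(OC)c2)cc1[N+](=O)[O-]` differs from compound 2 in carrying 4-methoxy-3-nitrophenyl in place of 4-methylphenyl on a saturated chain carbon bound to an amide-type nitrogen. Within the data shown here, no measured step exists to set a size. The expected change is an at least 3.3-fold lower number from compound 2 to compound 3 (0.52 log units; beyond the scatter) towards stronger inhibition, and a result at the same limit stays possible. Compound 3 is estimated at 6000 nM with an expected range from 300 nM to 20000 nM for now.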

Compound 3, half-maximal inhibitory concentration: 810 nM
Compound 3: middle estimate off by 7.4-fold (0.87 log units), on the high side; measured number inside the range.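

In this assay, the saturated chain carbon bound to an amide-type nitrogen proves to be a place where a change can turn a compound without a measurable value into one with a value: compound 3 gives 810 nM. The change, 4-methylbenzyl to 4-methoxy-3-nitrobenzyl, gives an at least 24-fold lower number from compound 2 to compound 3 (1.39 log units; beyond the scatter). That step has only a bound for its size, since compound 2 stands at a limit rather than a number: the limit of > 20000 nM in this assay, at which 2 of the 3 values shown sit.

Open, as far as these compounds go, is whether the nitro group, the methoxy group or both together carry the step. Also open, from the compounds shown here alone, is how an amine or a nitrile in place of the nitro group would read.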